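Notes on the step from compound 1 to compound 4

The source may report more compounds than this note shows. Statements on the series, on what has been measured and on what is new or still open speak of the compounds shown alone.

Measured in a functional assay on SH-SY5Y cells (Homo sapiens) for cytotoxicity, read by MTT assay, with stated times of 24 h and 4 h; a higher number here means that more compound is needed for the effect, a lower number that less compound is needed:
compound 1 `COc1cc(CNC(=O)/C=C/c2cccc(OCc3nc(C)c(C)nc3C)c2)ccc1O` gives 8090 nM
compound 2 `COc1cc(CNC(=O)/C=C/c2cccc(OCc3nc(C)c(C)nc3C)c2)ccc1OCc1nc(C)c(C)nc1C` gives 8700 nM
compound 3 `COc1cc(CNC(=O)/C=C/c2ccc(OC)c(OCc3nc(C)c(C)nc3C)c2)ccc1O` gives 9250 nM

Compound 1 stands within the scatter of both other compounds, with a 1.1-fold higher number from compound 1 to compound 2 (0.03 log units; within the scatter) and a 1.1-fold higher number from compound 1 to compound 3 (0.06 log units; within the scatter) as its measured steps. Compound 4 `COc1cccc(/C=C/C(=O)NCc2ccc(O)c(OC)c2)c1` differs from compound 1 by hydrogen in place of 3,5,6-trimethylpyrazin-2-yl on a saturated chain carbon bound to an oxygen on an aromatic ring and so carries methyl in that place. Going by the values given here, no measured step removes this group. Its addition on an oxygen on an aromatic ring, seen in compound 2 as a 1.1-fold higher number from compound 1 to compound 2 (0.03 log units; within the scatter), is the closest evidence, while the methoxy step bears less directly. No step beyond the scatter is therefore expected in this assay and no direction is favoured. The estimated step is a 1.1-fold higher number from compound 1 to compound 4 (0.05 log units; within the scatter) on thin evidence. For compound 4 the estimate is 9000 nM with an expected range of 3500 nM to 30000 nM.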

Compound 4, half-maximal effective concentration: 5240 nM
Compound 4: middle estimate off by 1.7-fold (0.23 log units), on the high side; measured number inside the range.
By their numbers in this assay, from the lowest: compounds 4, 1, 2 and 3 (each within the scatter of the next).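

In this assay, the 3,5,6-trimethylpyrazin-2-yl group on this saturated chain carbon bound to an oxygen on an aromatic ring can be replaced by hydrogen with a 1.5-fold lower number from compound 1 to compound 4 (0.19 log units; within the scatter) as the whole step. Compounds 1, 2 and 3 all carry this group there, so only compound 4 shows that the number stays within the scatter without it. Nothing measured here accounts for this result.

Still open, on these data alone, is whether an amine, a carboxylic acid or a longer chain in this place would give a step beyond the scatter.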